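Plasma stability notes on the hydroxymethyl to methoxymethyl step

A few compounds are considered here, and "the series" means these few. Any claim that something is new, unique, unknown or untested is made for them only; others in the source may bear on it.

Compound 1 `CC(=O)N1CCN(S(=O)(=O)c2ccc(F)cc2)CC1CO`: in an ADME assay on a cell-free system (plasma, Rattus norvegicus, strain Sprague-Dawley) for metabolic stability, read by LC-MS, tested at 1 uM (on this read-out lower numbers stand for a shorter-lived compound and higher numbers for a longer-lived compound), compound 1 gives >= 4 h, which is a limit of the assay and not a number.
Compound 2 `CC(=O)N1CCN(S(=O)(=O)c2ccc(F)cc2)C(CO)C1`: in this assay compound 2 gives >= 4 h, again a limit.
Compound 3 `COCC1CN(S(=O)(=O)c2ccc(F)cc2)CCN1C(C)=O`: in this assay compound 3 gives >= 4 h, again a limit.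

Compound 2 therefore stands at the limit of this assay, where every measured value in this set sits (the limit of >= 4 h in this assay, at which 3 of the 3 values shown sit). The change to compound 4 `COCC1CN(C(C)=O)CCN1S(=O)(=O)c1ccc(F)cc1` is methyl in place of hydrogen on an oxygen on a saturated carbon, hydroxymethyl to methoxymethyl. Among the compounds with values here, the one measured step of the same kind, a step that the two limits leave unreadable from compound 1 to compound 3, cannot be read because the limit of >= 4 h in this assay, at which 3 of the 3 values shown sit, covers both of its ends. No shift beyond the scatter is expected; the estimated step that the limit leaves unreadable from compound 2 to compound 4 is expected to be small. For compound 4 the expected half-life in this assay is 6 h, within 3 h to 12 h, and most probably reported once more only as a limit.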

Compound 4, half-life: >= 4 h
Compound 4: a limit, no number; the forecaster's own chance of this, stated with the estimate: 85%; the middle value lies beyond the limit too.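

No step can be read between compound 2 and compound 4 because both sit at the same limit: the limit of >= 4 h in this assay, at which 4 of the 4 values shown sit.

The compounds shown leave open whether hydroxymethyl to methoxymethyl changes plasma half-life at all, since the true values remain hidden behind that limit.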